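Dropping One Chloro from the Core of Compound 1

A few compounds are considered here, and "the series" means these few. Any claim that something is new, unique, unknown or untested is made for them only; others in the source may bear on it.

Measured so far:
compound 1, `ClCc1cccc(Cn2cnc3c(Cl)nc(Cl)nc32)c1`, 3090 nM
compound 2, `ClCc1ccccc1Cn1cnc2ncnc(Cl)c21`, 10700 nM

Within the data shown here, in a functional assay on UO-31 cells (Homo sapiens) for cytotoxicity, read by sulforhodamine B assay, with a stated time of 48 h (on this read-out lower numbers stand for stronger inhibition of growth and higher numbers for weaker inhibition of growth), compound 1 gives 3090 nM, the lowest of the two numbers known here. Compound 2 gives 10700 nM, a difference beyond the usual scatter. Compound 3 `ClCc1cccc(Cn2cnc3c(Cl)ncnc32)c1` has not been measured; it differs from compound 1 only by hydrogen in place of chloro on an aromatic carbon. Among the measured compounds shown here, no step between two measured compounds that differ in one place is known, so the effect of this change must be estimated. A moderate rise in the number, somewhat beyond the scatter, is expected as a 2.3-fold higher number from compound 1 to compound 3 (0.36 log units; beyond the scatter). Compound 3 is therefore estimated at 7000 nM, with a range from 2500 nM to 20000 nM.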

Compound 3, concentration for total growth inhibition: 36300 nM
Compound 3: middle estimate off by 5.2-fold (0.71 log units), on the low side, and the stated range ends below it.
By their numbers in this assay, from the lowest: compound 1; then compound 2; then compound 3.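

In this assay, among these compounds, the chloro on the aromatic carbon between two ring nitrogen atoms proves to matter: hydrogen in its place gives a 12-fold higher number from compound 1 to compound 3 (1.07 log units; beyond the scatter) and this is the first step read at a single place. This position is therefore one where a single atom change moves the number by a large amount. Nothing at hand explains the size of this step. Going by these compounds, whether an amine or a methoxy group at this position would keep the number of compound 1 remains open. Also open, on these data alone, is whether removing this chloro gives a similar step when the chloromethyl group sits as in compound 2.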